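Adding an Ethyl Group to Compound 2

This account rests on a few compounds, and the source may have more. Where it says the series, first, only, none or still open, it means among the compounds named here.

Measured in a functional assay on DU-145 cells (Homo sapiens) for inhibition, read by CCK-8 assay, with a stated time of 72 h; a higher number here means a weaker inhibitor, a lower number a stronger inhibitor:
- compound 1 `O=C(/C=C/c1cccnc1)NCCCCCc1cccc(S(=O)(=O)Nc2ccccc2)c1`: 140 nM
- compound 2 `O=C(/C=C/c1cccnc1)NCCCCCCc1cccc(S(=O)(=O)Nc2ccccc2)c1`: 6.73 nM
- compound 3 `O=C(/C=C/c1cccnc1)NCCCCCCCc1cccc(S(=O)(=O)Nc2ccccc2)c1`: 429 nM

These three compounds differ only in the length of their chain, with compound 1 carrying a shorter one and compound 3 a longer one than compound 2. Compound 2 has the lowest number of the three, making it the strongest inhibitor in the series. Compound 1 and compound 3 both lie above it by margins well beyond the scatter.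

The next compound to be tested is compound 4 `CCc1ccc(NS(=O)(=O)c2cccc(CCCCCCNC(=O)/C=C/c3cccnc3)c2)cc1`, which keeps the chain of compound 2 and changes the phenyl group to 4-ethylphenyl: ethyl in place of hydrogen on an aromatic carbon. The new ethyl group sits on an aromatic carbon, para to a large group. Among the measured compounds shown here, no measured compound carries a substituent on this ring, so the data offer no direct guide to this change. Because compound 2 stands at 6.73 nM at the low end of the series, a modest rise is more likely than a further fall, though a step within the scatter remains possible. The expected change is a 2.2-fold higher number from compound 2 to compound 4 (0.35 log units; beyond the scatter). For compound 4 the estimated value is 15 nM, with an expected range of 4 nM to 60 nM.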

Compound 4, half-maximal inhibitory concentration: 40.1 nM
The estimate for compound 4 lay 2.7-fold (0.43 log units) below the measured number; the measured number falls inside the stated range.
By their numbers in this assay, from the lowest: compound 2; then compound 4; then compound 1; then compound 3.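

In this assay, ethyl in place of hydrogen on the phenyl group of compound 2 gives a 6.0-fold higher number from compound 2 to compound 4 (0.78 log units; beyond the scatter), so this aromatic carbon, para to a large group, is not indifferent to what it carries. The earlier compounds shown here differ only in their chains and say nothing about this ring, whereas this single step shows that the ring, too, can shift the number beyond the scatter, although compound 4, at 40.1 nM, still inhibits in the nanomolar range. Nothing available here accounts for the size or direction of this step.

A methyl group, a fluorine atom or a methoxy group on the same carbon would show whether the rise is particular to ethyl or comes with any replacement of hydrogen there, and ethyl on the other carbons of the ring would show whether this place is unusual. Also open, going by these compounds, is whether the shorter and longer chains of compound 1 and compound 3 would keep their order relative to compound 2 once phenyl is replaced by 4-ethylphenyl.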